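From 3,4,5-Trimethoxyphenyl to 4-Chlorophenyl on a Shared Core

This account rests on a few compounds, and the source may have more. Where it says the series, first, only, none or still open, it means among the compounds named here.

In an ADME assay on Vero cells (Chlorocebus sabaeus) for cytotoxicity, read by MTT assay, with a stated time of 72 h (a lower number here means that less compound is tolerated, a higher number that more compound is tolerated), compound 1 `COc1cc(-c2cc(-c3ccc(C4NC(=O)c5ccccc5N4)cc3)nc(N)n2)cc(OC)c1OC` gives 85900 nM. Within the data shown here, this is the only number available, so compound 1 cannot be ranked against anything. For a second compound, compound 2 `CC1(c2ccc(NC(c3ccncc3)c3nnnn3C(C)(C)C)cc2)NC(=O)c2ccccc2N1`, the entry reads "not determined" (no result reported), which offers no comparison.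

The next compound to be tested is compound 3 `Nc1nc(-c2ccc(Cl)cc2)cc(-c2ccc(C3NC(=O)c4ccccc4N3)cc2)n1`, which keeps the core of compound 1 and changes a single substituent. A 4-chlorophenyl stands in place of 3,4,5-trimethoxyphenyl on an aromatic carbon of the six-membered ring with 2 nitrogen, meta to the amino group: 4-chlorophenyl in place of 3,4,5-trimethoxyphenyl on an aromatic carbon.

Among the measured compounds shown here, no measured pair shows what a change of this kind does in this assay, so the expectation rests on little more than the starting value of compound 1 at 85900 nM. A modest move toward less compound being tolerated seems the likelier outcome, though a result within the usual scatter would be no surprise. The expected change is a 1.4-fold lower number from compound 1 to compound 3 (0.16 log units; within the scatter). For compound 3 the estimated value is 60000 nM, with an expected range from 20000 nM to 160000 nM.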

Compound 3, half-maximal cytotoxic concentration: 323000 nM
For compound 3 the middle estimate is 5.4-fold (0.73 log units) below the measured one, and the stated range ends below it.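

In this assay, 4-chlorophenyl in place of 3,4,5-trimethoxyphenyl on this aromatic carbon gives a 3.8-fold higher number from compound 1 to compound 3 (0.58 log units; beyond the scatter) and thus shows that the group held here on the shared core can shift how much compound the cells tolerate. The change is also a large exchange of atoms: 3,4,5-trimethoxyphenyl, with 12 heavy atoms and 3 hydrogen-bond acceptors, leaves, while 4-chlorophenyl, with 7 heavy atoms and 0 hydrogen-bond acceptors, enters, so this single step cannot separate the loss of the three methoxy groups from the arrival of the chlorine. Nothing measured beyond these values helps to explain the higher number.

The compounds shown leave open whether an unsubstituted phenyl or a 4-methoxyphenyl at this position would stand nearer to compound 1 or to compound 3. They also leave open whether a 4-bromophenyl or a 4-fluorophenyl would give a step of similar size, and whether the same exchange would carry over to any other core.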